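The source may report more compounds than this note shows. Statements on the series, on what has been measured and on what is new or still open speak of the compounds shown alone.

Working notes on the series.

The shared core of compound 1 `Cc1nc2cnccc2n1C1CCN(C(=O)CC(c2ccccc2)c2ccccc2)CC1` carries a diphenyl-bearing amide chain on the ring nitrogen. For the measured compounds named here, in a functional assay on the whole organism (arterial blood) with Rattus norvegicus as the target (a higher number here means that more compound is needed for the effect, a lower number that less compound is needed), compound 1 gives 0.41 mg/kg, the second highest of the three numbers so far. Going by the values given here, compound 2 `COC(=O)NC(CC(=O)N1CCC(n2c(C)nc3cnccc32)CC1)c1ccccc1` gives 0.56 mg/kg; the step of a 1.4-fold higher number from compound 1 to compound 2 (0.14 log units; within the scatter) is the only measured one-place step in the set, and it concerns the chain, not the place altered below. Among the compounds with values here, compound 3 `Cc1nc2cnccc2n1CC1CCN(S(=O)(=O)CC(C)(C)c2ccccc2)CC1` gives 0.087 mg/kg, the lowest of the three, but it differs from compound 1 both in the chain and at the saturated ring carbon, so its two values against compound 1 show only that the larger ring-carbon substituent is compatible with a low number when paired with a different chain.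

Compound 4 `Cc1nc2cnccc2n1CC1CCN(C(=O)CC(c2ccccc2)c2ccccc2)CC1` differs from compound 1 in one place: a group of 11 heavy atoms (8 carbon, 3 nitrogen; one five-membered aromatic ring with 2 hetero atoms, one six-membered aromatic ring with 1 hetero atom) in place of a group of 10 heavy atoms (7 carbon, 3 nitrogen; one five-membered aromatic ring with 2 hetero atoms, one six-membered aromatic ring with 1 hetero atom), on a saturated ring carbon

Within the data shown here, no measured step bears directly on this change; the step from compound 1 to compound 2 is within the scatter and sits elsewhere. The expectation for this assay is therefore a step no larger than the scatter, with a lean toward a lower number given what compound 3 shows in 0.087 mg/kg. For compound 4 the estimated value is 0.3 mg/kg, with a range from 0.1 mg/kg to 0.9 mg/kg, and the step it implies is a 1.4-fold lower number from compound 1 to compound 4 (0.14 log units; within the scatter).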

Compound 4, dose for 50% inhibition: 0.0086 mg/kg
Compound 4: the middle estimate sits 35-fold (1.54 log units) above what was measured, and the stated range ends above it.
By their numbers in this assay, from the lowest: compound 4; then compound 3; then compounds 1 and 2 (each within the scatter of the next).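

The step in this assay is a 48-fold lower number from compound 1 to compound 4 (1.68 log units; beyond the scatter), which shows that this saturated ring carbon, three ring bonds from the ring nitrogen, is highly sensitive to the change from the group of 10 heavy atoms to the group of 11 heavy atoms, although the two groups match in their aromatic rings, hydrogen-bond donors, hydrogen-bond acceptors and lack of net charge. For the compounds shown here, the earlier one-place step, a 1.4-fold higher number from compound 1 to compound 2 (0.14 log units; within the scatter), lay in the chain and stayed within the scatter, so this is the first step to go beyond the scatter, and it shows that this position can carry far more of the change in the number than that chain change did. No measurement of any other property accompanies the result, so the data offer no explanation for the size of the step.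

Resting on a single pair, the step does not show whether it would keep its size with other chains on the ring nitrogen. Also open, from the compounds shown here alone, is whether a group with a longer carbon chain, or with an amine in that chain, at this ring carbon would keep the number this low.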